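A few compounds are considered here, and "the series" means these few. Any claim that something is new, unique, unknown or untested is made for them only; others in the source may bear on it.

Measured compounds in a functional assay on A549 cells (Homo sapiens) for antiproliferative activity, read by MTT assay, with a stated time of 72 h; a higher number here means a weaker inhibitor, a lower number a stronger inhibitor:
Compound 1 `C/C=C/C(=O)Nc1cc2c(N3CCc4ccccc43)ncnc2cc1OC` gives 8290 nM.
Compound 2 `CCC/C=C/C(=O)Nc1cc2c(N3CCc4ccccc43)ncnc2cc1OC` gives 2920 nM.
Compound 3 `CCC/C=C/C(=O)Nc1cc2c(N3CCCc4ccccc43)ncnc2cc1OC` gives 1800 nM.

Among these three numbers compound 2 stands second highest: its nearest neighbour is compound 3, separated by a 1.6-fold lower number from compound 2 to compound 3 (0.21 log units; within the scatter), and its furthest is compound 1, separated by a 2.8-fold lower number from compound 1 to compound 2 (0.45 log units; beyond the scatter).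

Compound 4 `COc1cc2ncnc(N3CCc4ccccc43)c2cc1NC(=O)/C=C/CN1CCN(C)CC1` differs from compound 2 by 4-methylpiperazin-1-yl in place of ethyl on a saturated chain carbon bound to a double-bonded chain carbon. Going by the values given here, only the step from compound 1 to compound 2, a 2.8-fold lower number from compound 1 to compound 2 (0.45 log units; beyond the scatter), touches the same place, and it shows that a change there moves this assay modestly. Among the compounds with values here, no measured compound carries a piperazine, so the direction of this larger swap cannot be read from the data. A step of about a 1.5-fold lower number from compound 2 to compound 4 (0.16 log units; within the scatter) is therefore expected, within the scatter. Compound 4 is estimated at 2000 nM, between 500 nM and 8000 nM.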

Compound 4, half-maximal inhibitory concentration: 5360 nM
Compound 4: middle estimate off by 2.7-fold (0.43 log units), on the low side, within the range that was stated.
By their numbers in this assay, from the lowest: compounds 3, 2, 4 and 1 (each within the scatter of the next, the first and the last beyond it).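

In this assay, putting 4-methylpiperazin-1-yl on the saturated chain carbon bound to a double-bonded chain carbon gives a value that cannot be told apart from that of the ethyl compound (a 1.8-fold higher number from compound 2 to compound 4 (0.26 log units; within the scatter)) or that of the compound with hydrogen there (a 1.5-fold lower number from compound 1 to compound 4 (0.19 log units; within the scatter)). This position therefore accepts a ring with two nitrogens without a step beyond the scatter, although compound 1 and compound 2 do differ beyond it. Nothing available offers a reason for this. Still open, going by these compounds, is how a dimethylamino group, a morpholine or a longer chain would read here, and whether 4-methylpiperazin-1-yl gives the same reading with the 1,2,3,4-tetrahydroquinolin-1-yl group of compound 3.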